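Working notes: compound 2 to compound 4, ethyl for diethylamino

The compounds below may be only part of what the source reports. "The series", "measured", "known", "first", "only" and "open" are said of these compounds alone.

Three compounds carry numbers. In a functional assay on the whole organism with Mus musculus as the target, in the writhing test (on this read-out higher numbers stand for an effect only at larger amounts of compound and lower numbers for an effect already at smaller amounts), compound 2 `CCN(CC)CCn1nc2oc(=O)cc(C)c2c1C` gives 100 mg/kg, and compound 1 `CCCn1nc(C)c2c(C)cc(=O)oc21` gives 54.3 mg/kg; these two lie within the usual scatter of each other. For compound 3 `CCOC(=O)Cc1nnc2oc(O)cc(C)c1-2` the read-out is > 100 mg/kg — the limit of > 100 mg/kg in this assay, at which 1 of the 3 values shown sits — and not a number. Compound 4 `CCCCn1nc2oc(=O)cc(C)c2c1C` is not yet measured; it differs from compound 2 by ethyl in place of diethylamino on a saturated chain carbon, two bonds along the chain from an aromatic nitrogen. Within the data shown here, no measured pair shows this change. Compound 1, which also lacks the diethylamino group, sits at 54.3 mg/kg. The expected step of a 1.7-fold lower number from compound 2 to compound 4 (0.22 log units; within the scatter) is small, toward lower numbers, and not beyond the scatter. Compound 4 is estimated at 60 mg/kg, between 25 mg/kg and 150 mg/kg.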

Compound 4, dose for half-maximal effect: > 100 mg/kg
Compound 4: no number, only a limit (the forecaster's own chance of this, stated with the estimate: 20%); at least 1.6-fold (0.22 log units) between middle value and limit.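

Ethyl in place of diethylamino on a saturated chain carbon, two bonds along the chain from an aromatic nitrogen, gives in this assay a number no lower from compound 2 to compound 4 (the limit leaves the size open). Among these compounds, this is the first direct reading at this position, and losing the diethylamino group here brings no shift toward lower numbers. Compound 4 stands at a limit of the assay, not at a number: the limit of > 100 mg/kg in this assay, at which 2 of the 4 values shown sit.

As far as these compounds go, the size of the step stays open. Also open, from the compounds shown here alone, is whether a dimethylamino group or a carboxylic acid in the same place would give a readable number.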